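This account rests on a few compounds, and the source may have more. Where it says the series, first, only, none or still open, it means among the compounds named here.

Measured so far:
Compound 1, `O=S(=O)(Nc1cccc2c1CCCC2c1c[nH]cn1)C1CC1`, gives 51% in a functional assay on Urethra with Alpha-1A adrenergic receptor (Oryctolagus cuniculus) as the target; a higher number here means a larger maximal response, a lower number a smaller maximal response.
Compound 2, `CCS(=O)(=O)Nc1cccc(Cc2c[nH]cn2)c1C`, gives 69% in this assay.
Compound 3, `COc1ccc(NS(C)(=O)=O)c2c1C(c1c[nH]cn1)CCC2`, gives 57% in this assay.

Compound 1 stands at the lowest of these three numbers. Compound 3 is its nearest neighbour, and the gap between the two lies within the scatter of repeated measurements, so no order between compound 1 and compound 3 can be read from them. Compound 2 is the furthest away, and that gap lies beyond the scatter, so compound 2 does reach a larger maximal response than compound 1.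

The next compound, compound 4, is `CN(c1cccc2c1CCCC2c1c[nH]cn1)S(C)(=O)=O`, and it has not yet been measured. It differs from compound 1 in one place: methyl(methylsulfonyl)amino in place of (cyclopropylsulfonyl)amino on an aromatic carbon. The entering group carries no hydrogen-bond donor, whereas the leaving group carries one.

Within the data shown here, no two measured compounds differ in only one place, so there is no measured step to lean on. The three measured numbers sit fairly close together, and nothing in them points one way or the other. The step from compound 1 to compound 4 is therefore expected to stay within the scatter, in either direction: a number 1 percentage points higher from compound 1 to compound 4 (within the scatter). Compound 4 is expected to give about 52%, with a likely range from 32% to 72%.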

Compound 4, largest response reached (reported as efficacy), in percent of the reference or control that the assay uses: 79%
For compound 4 the middle estimate is 27 percentage points below the measured one, outside the stated range (above it).
By their numbers in this assay, from the lowest: compounds 1 and 3 (each within the scatter of the next); then compounds 2 and 4 (each within the scatter of the next).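

Among these compounds, on an aromatic carbon of the shared core, putting methyl(methylsulfonyl)amino in place of (cyclopropylsulfonyl)amino gives a number 28 percentage points higher from compound 1 to compound 4 (beyond the scatter) in this assay and is the first single change in this set, showing that the maximal response depends on the group at this position. The change is not a single feature, however: the entering group has no hydrogen-bond donor and no ring, whereas the leaving group has one donor and a three-membered ring of carbon, so this one step cannot show which difference matters. No measurement is available that explains the higher response.

The compounds shown leave open whether the ring or the donor accounts for the step, a question that methyl(cyclopropylsulfonyl)amino on the same carbon could help settle, since it keeps the ring and has no donor on the nitrogen. Also open, on these data alone, is how the response would change with ethyl(methylsulfonyl)amino, which carries a longer chain on the nitrogen, or with a simple amine at this position.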